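The source may report more compounds than this note shows. Statements on the series, on what has been measured and on what is new or still open speak of the compounds shown alone.

Measured so far in a functional assay on SW 1116 cells (Homo sapiens) for antiproliferative activity, read by MTT assay, with a stated time of 24 h; on this read-out lower numbers stand for stronger inhibition and higher numbers for weaker inhibition:
compound 1 `c1ccc(CSc2nnc(-c3ccc4c(c3)OCCO4)n2-c2ccccc2)cc1` gives 7930 nM
compound 2 `O=[N+]([O-])c1ccc(CSc2nnc(-c3ccc4c(c3)OCCO4)n2-c2ccccc2)cc1` gives 13800 nM
compound 3 `Fc1ccc(CSc2nnc(-c3ccc4c(c3)OCCO4)n2-c2ccccc2)cc1` gives 20800 nM

Compound 3 carries the highest of the three numbers in this assay. Its nearest neighbour is compound 2: a 1.5-fold higher number from compound 2 to compound 3 (0.18 log units; within the scatter), a gap within the scatter, so no order between these two can be read. The gap to compound 1 is wider: a 2.6-fold higher number from compound 1 to compound 3 (0.42 log units; beyond the scatter), modest but beyond the scatter.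

Compound 4 `Fc1ccc(CSc2nnc(-c3ccc4c(c3)OCCO4)n2-c2ccccc2)c(F)c1` is not yet measured. It differs from compound 3 by fluoro in place of hydrogen on an aromatic carbon. Within the data shown here, two measured steps bear on this: both add a single substituent on the same six-membered aromatic ring of carbon only, a 1.7-fold higher number from compound 1 to compound 2 (0.24 log units; within the scatter) and a 2.6-fold higher number from compound 1 to compound 3 (0.42 log units; beyond the scatter). Both went toward higher numbers, one within the scatter and one modestly beyond it. Nothing in the set shows what a second fluoro does on a ring that already carries one; the comparison a 1.5-fold higher number from compound 2 to compound 3 (0.18 log units; within the scatter) only sets two single substituents against each other. The expectation is therefore a small step toward a higher number, probably within the scatter: a 1.3-fold higher number from compound 3 to compound 4 (0.10 log units; within the scatter) is expected. Compound 4 is estimated at 26000 nM, with a range from 10000 nM to 65000 nM.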

Compound 4, half-maximal inhibitory concentration: 7830 nM
For compound 4 the middle estimate is 3.3-fold (0.52 log units) above the measured one; measured number outside the range, below it.
By their numbers in this assay, from the lowest: compounds 4, 1, 2 and 3 (each within the scatter of the next, the first and the last beyond it).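

In this assay, fluoro in place of hydrogen on this ring no longer moves the number in one direction: the first fluoro gave a 2.6-fold higher number from compound 1 to compound 3 (0.42 log units; beyond the scatter), whereas the second, ortho to a large group and meta to a fluoro group, gives a 2.7-fold lower number from compound 3 to compound 4 (0.42 log units; beyond the scatter), a modest step in the opposite direction. The two fluoro steps therefore do not add up across this series, and the 2,4-difluorobenzyl group cannot be told apart from the unsubstituted benzyl group, with a 1.0-fold lower number from compound 1 to compound 4 (0.01 log units; within the scatter), or from the 4-nitrobenzyl group, with a 1.8-fold lower number from compound 2 to compound 4 (0.25 log units; within the scatter). No measurement in hand explains the reversal of direction at this position.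

The compounds shown leave open whether the step belongs to the ortho fluoro itself or depends on the 4-fluoro already present, a question that a 2-fluorobenzyl group would address. They also leave open how this position responds to anything other than fluoro, such as a methoxy group, an amine or a carboxylic acid.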